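The source may hold more compounds than are shown below. What is called first, only, known or untested is meant among the compounds shown, and "the series" means these compounds.

Working notes on the series. Of the compounds shown here, two have been measured so far. Compound 1 `CC(C)NC(=O)c1cc(Oc2cccc(NC(=S)Nc3ccc(Cl)cc3)c2)ccn1` gives 21200 nM in a functional assay on PC-3 cells (Homo sapiens) for cytotoxicity, read by MTT assay, with a stated time of 48 h; on this read-out higher numbers stand for weaker inhibition and lower numbers for stronger inhibition. Compound 2 `O=C(NCc1ccccc1)c1cc(Oc2cccc(NC(=S)Nc3ccc(Cl)cc3)c2)ccn1` gives 15800 nM in this assay. Among the compounds with values here, the only single-point step between them is a 1.3-fold lower number from compound 1 to compound 2 (0.13 log units; within the scatter), benzyl in place of isopropyl on the amide-type nitrogen, so the two numbers are not distinguishable from each other. Compound 2 has the lower of the two numbers, but within the scatter, so no order between compound 1 and compound 2 can be claimed.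

Compound 3 `O=C(NCc1ccccc1)c1cc(Oc2cccc(NC(=S)Nc3cccc(C(F)(F)F)c3)c2)ccn1` has not yet been measured. It differs from compound 2 by 3-(trifluoromethyl)phenyl in place of 4-chlorophenyl on an amide-type nitrogen. Within the data shown here, no measured step touches this nitrogen, which sits on the thiocarbonyl side of the molecule; the one step known, a 1.3-fold lower number from compound 1 to compound 2 (0.13 log units; within the scatter), lies at the other amide and is itself within the scatter. There is therefore no measured basis for a direction, and the step from compound 2 to compound 3 in this assay is expected to be a 1.1-fold lower number from compound 2 to compound 3 (0.02 log units; within the scatter), that is, nothing beyond the scatter. The estimate for compound 3 is 15000 nM, with a range from 5000 nM to 45000 nM.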

Compound 3, half-maximal inhibitory concentration: 11000 nM
Compound 3: middle estimate off by 1.4-fold (0.13 log units), on the high side; low and high end bracket the measured number.
By their numbers in this assay, from the lowest: compounds 3, 2 and 1 (each within the scatter of the next).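

Within the data shown here, this is the first measured step at the amide-type nitrogen whose other neighbour is the thiocarbonyl carbon: in this assay, 3-(trifluoromethyl)phenyl in place of 4-chlorophenyl gives a 1.4-fold lower number from compound 2 to compound 3 (0.16 log units; within the scatter). A change to the aromatic group on this nitrogen, from 7 to 10 heavy atoms and with chlorine giving way to three fluorines, therefore leaves compound 2 and compound 3 indistinguishable in this read-out, just as a 1.3-fold lower number from compound 1 to compound 2 (0.13 log units; within the scatter) does for the change at the other amide. No measurement bears on why this swap leaves the two numbers within the scatter.

The step changes both the substituent and its place on the aromatic ring, and the compounds shown do not separate these two contributions. Going by these compounds, whether this nitrogen can move the number beyond the scatter at all remains open, for instance with a plain phenyl, or with an amine or a carboxylic acid on the ring.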